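Notes on the series: step from compound 3 to compound 4

A few compounds are considered here, and "the series" means these few. Any claim that something is new, unique, unknown or untested is made for them only; others in the source may bear on it.

Of the compounds shown here, three have been measured in a functional assay on A549 cells (Homo sapiens) for antiproliferative activity, read by MTT assay, with a stated time of 48 h; on this read-out higher numbers stand for weaker inhibition and lower numbers for stronger inhibition. Compound 1 `N#CC1=C(N)Oc2c(c3nc4ccccc4nc3c3ccccc23)C12C(=O)N(Cc1cnnn1-c1cccc(Br)c1)c1ccccc12` gives > 50000 nM in this assay, which is a limit of the assay. Compound 2 `Cc1cc(C)cc(-n2nncc2CN2C(=O)C3(C(C#N)=C(N)Oc4c3c3nc5ccccc5nc3c3ccccc43)c3ccccc32)c1` gives > 50000 nM in this assay, also a limit. The step that the two limits leave unreadable from compound 1 to compound 2 therefore cannot be read, as follows from the limit of > 50000 nM in this assay, at which 2 of the 3 values shown sit. Among the measured compounds shown here, compound 3 `COc1ccccc1-n1nncc1CN1C(=O)C2(C(C#N)=C(N)Oc3c(N)cc4nc5ccccc5nc4c32)c2ccccc21` is the only compound with a number: in this assay compound 3 gives 37500 nM. The values of compound 1 and compound 2 are limits.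

Compound 4 `COc1cc(-n2nncc2CN2C(=O)C3(C(C#N)=C(N)Oc4c(N)cc5nc6ccccc6nc5c43)c3ccccc32)c(OC)cc1Cl` is not yet measured. It differs from compound 3 by 4-chloro-2,5-dimethoxyphenyl in place of 2-methoxyphenyl on an aromatic nitrogen. For the measured compounds named here, no measured step bears directly on this change: the single step between compounds differing in one place, a step that the two limits leave unreadable from compound 1 to compound 2, sits between two limits, so its size is unknown, and no readable step at this position exists. No step beyond the scatter is therefore expected in this assay in either direction. Compound 4 is expected to give about 35000 nM in this assay, between 15000 nM and 80000 nM. The step of a 1.1-fold lower number from compound 3 to compound 4 (0.03 log units; within the scatter) is thus expected to lie within the scatter.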

Compound 4, half-maximal inhibitory concentration: > 50000 nM
Compound 4: a limit, no number; the forecaster's own chance of this, stated with the estimate: 35%; at least 1.4-fold (0.15 log units) between middle value and limit.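

In this assay, among the compounds shown here, the change from 2-methoxyphenyl to 4-chloro-2,5-dimethoxyphenyl on the aromatic nitrogen gives an at least 1.3-fold higher number from compound 3 to compound 4 (0.12 log units; that floor lies within the scatter) as the first step at this position that can be read at all, and it is readable only as a floor. Compound 4 sits at a limit of the assay and has no number. The entering group therefore brings no sign of stronger inhibition, yet the floor alone does not place compound 4 beyond the scatter from compound 3, and the read-out leaves little room at this end: the limit of > 50000 nM in this assay, at which 3 of the 4 values shown sit.

The compounds shown do not separate the chlorine from the added methoxy, so neither can be tied to the step on its own. As far as these compounds go, how a carboxylic acid or a dimethylamino group on this phenyl ring would read also stays open.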